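Adding Methoxy to the Benzoyl Ring of Compound 2

This account rests on a few compounds, and the source may have more. Where it says the series, first, only, none or still open, it means among the compounds named here.

Compound 1 `Nc1ccccc1NC(=O)c1ccc(CNC(=O)c2n[nH]cc2NC(=O)c2ccccc2Cl)cc1` gives 10500 nM
Compound 2 `Nc1ccccc1NC(=O)c1ccc(CNC(=O)c2n[nH]cc2NC(=O)c2ccccc2)cc1` gives 4060 nM
Compound 3 `O=C(NO)c1ccc(CNC(=O)c2n[nH]cc2NC(=O)c2c(Cl)cccc2Cl)cc1` gives 4840 nM

In a functional assay on HeLa cells (Homo sapiens) for inhibition, read by CCK-8 assay, with a stated time of 72 h (on this read-out lower numbers stand for stronger inhibition and higher numbers for weaker inhibition), compound 2 stands at 4060 nM and lies within the usual scatter of compound 3 (4840 nM), while compound 1 sits clearly higher, which here means weaker inhibition. The next compound to be tested is compound 4 (`COc1ccccc1C(=O)Nc1c[nH]nc1C(=O)NCc1ccc(C(=O)Nc2ccccc2N)cc1`), which keeps everything in compound 2 except for one change on the benzoyl ring: methoxy in place of hydrogen on an aromatic carbon, ortho to a large group.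

Going by the values given here, only one measured step touches this ring. It is a 2.6-fold lower number from compound 1 to compound 2 (0.41 log units; beyond the scatter) and it shows that a chloro group on this ring goes with a higher number than hydrogen. Compound 3 differs from compound 2 in more than one place, so it offers no direct comparison. Among the compounds with values here, no methoxy compound has been measured, and a single step sets no rule. Even so, a small rise seems the most reasonable expectation, no larger than the chloro step. The estimated change is a 1.7-fold higher number from compound 2 to compound 4 (0.24 log units; within the scatter) in the same direction as that chloro difference. Compound 4 is expected at about 7000 nM in this assay with an estimated range from 2800 nM to 17000 nM as its limits.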

Compound 4, half-maximal inhibitory concentration: 8130 nM
Compound 4: middle estimate off by 1.2-fold (0.06 log units), on the low side; low and high end bracket the measured number.
By their numbers in this assay, from the lowest: compounds 2, 3, 4 and 1 (each within the scatter of the next, the first and the last beyond it).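

In this assay the move to the methoxy group, ortho to a large group, gives a 2.0-fold higher number from compound 2 to compound 4 (0.30 log units; within the scatter) and so cannot be told apart from hydrogen at this place. Putting methoxy in place of chloro at the same place gives a 1.3-fold lower number from compound 1 to compound 4 (0.11 log units; within the scatter) and so cannot be told apart from chloro either, even though the earlier step of a 2.6-fold lower number from compound 1 to compound 2 (0.41 log units; beyond the scatter) does separate chloro from hydrogen. This position therefore accepts a group of two heavy atoms without a change that can be read beyond the scatter, but nothing measured here explains these numbers.

The compounds shown leave open whether an amine, a carboxylic acid or a longer chain such as ethoxy at this same place would give a number clearly apart from that of compound 2. They also leave open whether methoxy in place of hydrogen would read the same way in a compound carrying the other end group seen in compound 3, which differs from the rest in more than one place.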